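A Carbamate Arm Replaces Propyl on the Hydroxy Chain

This account rests on a few compounds, and the source may have more. Where it says the series, first, only, none or still open, it means among the compounds named here.

Compound 1 `O=C(OCC(O)Cn1cc(CN2CCN(c3ccccc3)CC2)nn1)c1ccccc1`: 11%
Compound 2 `CCCCC(O)Cn1cc(CN(C)CCCc2ccccc2)nn1`: 37%
Compound 3 `CCCCC(O)Cn1cc(CN(C)CCC(C)C)nn1`: 47%

In an assay on nucleic acid for inhibition of Nucleic Acid, read by fluorescence, tested at 100 uM (a lower number here means less inhibition, a higher number more inhibition at the concentration tested (going by the name of the read-out)), compound 3 gives the highest of the three numbers; the step of a number 10 percentage points higher from compound 2 to compound 3 (within the scatter) is within the scatter, while compound 1 lies well below compound 3, beyond the scatter. Compound 4 `CCCCNC(=O)OCC(O)Cn1cc(CN(C)CCC(C)C)nn1` differs from compound 3 by (butylcarbamoyl)oxy in place of propyl on a saturated chain carbon, two bonds along the chain from an oxygen on a saturated carbon. Among the measured compounds shown here, the only recorded step, a number 10 percentage points higher from compound 2 to compound 3 (within the scatter), concerns the amine end and is within the scatter, so it says little about this change. Compound 1, which also carries an oxygen-linked carbonyl group on a saturated chain carbon two bonds along the chain from an oxygen on a saturated carbon, gives 11%. A drop toward that value is therefore expected for compound 4, a number 17 percentage points lower from compound 3 to compound 4 (beyond the scatter). Compound 4 is estimated at 30%, between 10% and 50%.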

Compound 4, a percentage reported as inhibition, at one concentration (the size of the read-out at that concentration, not a potency): 24%
For compound 4 the middle estimate is 6 percentage points above the measured one, and the stated range covers the measured number.
By their numbers in this assay, from the lowest: compound 1; then compound 4; then compounds 2 and 3 (each within the scatter of the next).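

In this assay, (butylcarbamoyl)oxy in place of propyl gives a number 23 percentage points lower from compound 3 to compound 4 (beyond the scatter) on this saturated chain carbon. The only earlier step lay at the amine end and within the scatter, so this is the first change shown to move the number beyond it, here downward. No measured evidence explains the fall.

The compounds shown leave open whether the carbamate link or the added length matters. A longer alkyl chain, or a methoxy group, at this position could help separate the two.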